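The source may hold more compounds than are shown below. What is called first, only, known or untested is meant among the compounds shown, and "the series" means these compounds.

Compound 1 `COc1cccc(C(=O)Nc2cccc(C(=O)O)c2)c1`: 1040 nM
Compound 2 `O=C(O)c1cccc(NC(=O)c2cccc(OCC3CC3)c2)c1`: 1260 nM

In an assay on isolated protein for agonist activity at Bile acid receptor (Homo sapiens), read by TR-FRET, with a stated time of 3 h, in the absence of a further agent (on this read-out higher numbers stand for an effect only at larger amounts of compound and lower numbers for an effect already at smaller amounts), compound 2 stands together with compound 1, the two separated only by a 1.2-fold higher number from compound 1 to compound 2 (0.08 log units; within the scatter). Compound 3 `O=C(O)c1cccc(NC(=O)c2cccc(OCc3ccccc3)c2)c1` carries phenyl in place of cyclopropyl on a saturated chain carbon bound to an oxygen on an aromatic ring. For the measured compounds named here, the one measured step that touches this place, a 1.2-fold higher number from compound 1 to compound 2 (0.08 log units; within the scatter), stayed within the scatter when cyclopropyl replaced hydrogen there, so for compound 3 the expected step in this assay is a 1.0-fold higher number from compound 2 to compound 3 (0.01 log units; within the scatter), none beyond the scatter. Compound 3 is therefore estimated at 1300 nM, with a range from 550 nM to 3200 nM.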

Compound 3, half-maximal effective concentration: 1160 nM
The estimate for compound 3 lay 1.1-fold (0.05 log units) above the measured number; the measured number falls inside the stated range.
By their numbers in this assay, from the lowest: compounds 1, 3 and 2 (each within the scatter of the next).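

With phenyl in place of cyclopropyl, in this assay the number stays within the scatter (a 1.1-fold lower number from compound 2 to compound 3 (0.04 log units; within the scatter)), and it does so also with phenyl in place of hydrogen (a 1.1-fold higher number from compound 1 to compound 3 (0.05 log units; within the scatter)). This place, on a saturated chain carbon bound to an oxygen on an aromatic ring, thus carries an aromatic ring of 6 heavy atoms as well as a non-aromatic ring of 3 without any step beyond the scatter. No measurement bears on why these numbers stay together.

On these data alone, it remains open whether an amine, a carboxylic acid or a longer chain at this place would give a step beyond the scatter.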